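Swapping a hydroxymethyl for tert-butoxy on a pyrrolidine carbonyl

The source may hold more compounds than are shown below. What is called first, only, known or untested is meant among the compounds shown, and "the series" means these compounds.

Compound 1, `CN1CCN(c2ccc(Nc3ncc4nc(Nc5ccccc5)n([C@@H]5CCN(C(=O)OC(C)(C)C)C5)c4n3)cc2)CC1`: 12 nM
Compound 2, `CN1CCN(c2ccc(Nc3ncc4nc(Nc5ccc(F)cc5)n([C@H]5CCN(C(=O)CO)C5)c4n3)cc2)CC1`: 380 nM
Compound 3, `CN1CCN(c2ccc(Nc3ncc4nc(Nc5ccc(F)cc5)n([C@H]5CCCC(NC(=O)OC(C)(C)C)C5)c4n3)cc2)CC1`: 120 nM

Of the compounds shown here, three sharing one core have been measured in a functional assay on HCC827 cells (Homo sapiens) for antiproliferative activity, read by MTT assay, with a stated time of 72 h; a lower number here means a stronger inhibitor, a higher number a weaker inhibitor. Compound 1 gives 12 nM, and compound 3 gives 120 nM. Compound 2 stands at the high end of these three numbers with 380 nM; the nearest of the others is compound 3, and the gap to compound 1 is the widest, both gaps lying beyond the scatter of this assay. Going by the values given here, no single-point step between measured compounds is available, so compound 2 can only be set against the others by its value.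

Compound 4, `CN1CCN(c2ccc(Nc3ncc4nc(Nc5ccc(F)cc5)n([C@H]5CCN(C(=O)OC(C)(C)C)C5)c4n3)cc2)CC1`, has not yet been measured in this assay. It differs from compound 2 in one place: tert-butoxy in place of hydroxymethyl on a carbonyl carbon. Because compound 2 gives 380 nM while compound 1, which carries the same tert-butoxycarbonyl group, gives 12 nM, a lower number is expected for compound 4, with a step of a 4.8-fold lower number from compound 2 to compound 4 (0.68 log units; beyond the scatter) beyond the scatter. Compound 4 is estimated at 80 nM, within a range from 25 nM to 300 nM.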

Compound 4, half-maximal inhibitory concentration: 580 nM
Beside the measured number, compound 4's estimate is 7.3-fold (0.86 log units) below it, and the stated range ends below it.
By their numbers in this assay, from the lowest: compound 1; then compound 3; then compounds 2 and 4 (each within the scatter of the next).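

At this position on the pyrrolidine carbonyl, the change from hydroxymethyl to tert-butoxy in this assay gives a 1.5-fold higher number from compound 2 to compound 4 (0.18 log units; within the scatter). The hydrogen-bond donor of hydroxymethyl can therefore be lost and four carbons brought in without the number moving beyond the scatter, so this pair shows a change at the carbonyl that the read-out does not separate. The step says nothing direct about compound 1, which differs from compound 4 in more than one place, and no measurement at hand bears on why these two groups read alike.

Still open, from the compounds shown here alone, is whether an aminomethyl group, a carboxylic acid or a longer chain on this carbonyl would shift the number beyond the scatter. Also open is how much of the spread among these compounds lies elsewhere in the molecule.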